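The source may report more compounds than this note shows. Statements on the series, on what has been measured and on what is new or still open speak of the compounds shown alone.

Measured in a functional assay on B16-F10 cells (Mus musculus) for inhibition, read by MTT assay, with a stated time of 48 h; on this read-out lower numbers stand for stronger inhibition and higher numbers for weaker inhibition:
- compound 1 `COc1ccc(/C=C/c2cc(OC)cc(OC)c2/C=C/C(=O)N2CCC(Cl)CC2)cc1`: 4690 nM
- compound 2 `CCCCCCNC(=O)/C=C/c1c(/C=C/c2ccc(OC)cc2)cc(OC)cc1OC`: 7180 nM
- compound 3 `COc1ccc(/C=C/c2cc(OC)cc(OC)c2/C=C/C(=O)N2CCCC(C)C2)cc1`: 8250 nM

Compound 3, at 8250 nM, sits within the scatter of both other compounds, so this assay does not separate the three. Next comes compound 4 `COc1ccc(/C=C/c2cc(OC)cc(OC)c2/C=C/C(=O)N2CCN(C)CC2)cc1`, with 4-methylpiperazin-1-yl in place of 3-methylpiperidin-1-yl on a carbonyl carbon. Among the measured compounds shown here, no measured step covers this exchange directly. The nearest evidence is the other exchanges on that carbonyl carbon: a 1.8-fold higher number from compound 1 to compound 3 (0.25 log units; within the scatter), a 1.1-fold higher number from compound 2 to compound 3 (0.06 log units; within the scatter) and a 1.5-fold higher number from compound 1 to compound 2 (0.18 log units; within the scatter). All stay within the scatter, so no step beyond the scatter is expected in this assay, and no clear direction. The expected step is a 1.2-fold lower number from compound 3 to compound 4 (0.07 log units; within the scatter). Compound 4 is estimated at 7000 nM, with an expected range of 3500 nM to 14000 nM.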

Compound 4, half-maximal inhibitory concentration: 5670 nM
Estimate against measurement, compound 4: 1.2-fold (0.09 log units) above; low and high end bracket the measured number.
By their numbers in this assay, from the lowest: compounds 1, 4, 2 and 3 (each within the scatter of the next).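

On this carbonyl carbon, 4-methylpiperazin-1-yl adds a second ring nitrogen and a hydrogen-bond acceptor, yet this assay still does not separate it from the other groups: the steps read a 1.5-fold lower number from compound 3 to compound 4 (0.16 log units; within the scatter) and a 1.3-fold lower number from compound 2 to compound 4 (0.10 log units; within the scatter) and a 1.2-fold higher number from compound 1 to compound 4 (0.08 log units; within the scatter). The three piperidine or piperazine groups and hexylamino therefore remain indistinguishable in this series, now including a ring with two hetero atoms. No supporting measurement bears on this result. On these data alone, whether a morpholin-4-yl group or a piperidine carrying a carboxylic acid would give a step beyond the scatter remains open. Changes on the shared core also remain open.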